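Triazine series: phenethyl replacing methoxybenzyl on the amine

The source may hold more compounds than are shown below. What is called first, only, known or untested is meant among the compounds shown, and "the series" means these compounds.

Measured compounds, values in a functional assay on cells for positive allosteric modulation of G-protein coupled receptor 68 (Homo sapiens), read by a luciferase reporter and cAMP accumulation, with a stated time of 30 min, at pH 6.8 and pH 8.3, in the presence of a further agent that is not named here; on this read-out lower numbers stand for lower potency and higher numbers for higher potency (the scale is a negative logarithm):
compound 1 `Nc1nc(NCc2cccc(Cl)c2)nc(-c2ccccc2CO)n1` gives 4.97
compound 2 `Cc1cccc(CNc2nc(N)nc(-c3ccccc3CO)n2)c1` gives 4.4
compound 3 `COc1ccc(CNc2nc(N)nc(-c3ccccc3CO)n2)cc1` gives 3.34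

Compound 3 stands lowest of the three numbers in this assay; its nearest neighbour is compound 2, and compound 1 lies furthest above it. Both steps into compound 3 are large: a number 1.63 log units lower from compound 1 to compound 3 (beyond the scatter) and a number 1.06 log units lower from compound 2 to compound 3 (beyond the scatter), while the exchange of chloro for methyl, a number 0.57 log units lower from compound 1 to compound 2 (beyond the scatter), is modest.

Compound 4 `Nc1nc(NCCCc2ccccc2)nc(-c2ccccc2CO)n1` is not yet measured. It differs from compound 3 by phenethyl in place of 4-methoxyphenyl on a saturated chain carbon bound to a nitrogen on an aromatic ring. For the measured compounds named here, no measured step bears directly on this change: every measured step swaps one substituted phenyl for another on the same saturated chain carbon, whereas here the 4-methoxyphenyl leaves entirely and an unsubstituted phenethyl enters. The measured steps show only that 4-methoxyphenyl sits at the bottom of the series and that the other two aryl groups run higher. On that basis a rise from compound 3 to compound 4 in this assay is expected, of a size between modest and large, with wide uncertainty; the expected step is a number 0.86 log units higher from compound 3 to compound 4 (beyond the scatter). Compound 4 is estimated at 4.2, with a range from 3.3 to 5.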

Compound 4, negative logarithm of the antagonist equilibrium constant: 5.22
Estimate against measurement, compound 4: 1.02 log units below; the whole stated range lies below it.
By their numbers in this assay, from the lowest: compound 3; then compound 2; then compounds 1 and 4 (each within the scatter of the next).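

In this assay, phenethyl in place of 4-methoxyphenyl on a saturated chain carbon bound to a nitrogen on an aromatic ring gives a number 1.88 log units higher from compound 3 to compound 4 (beyond the scatter), and the same kind of exchange starting from the 3-methylphenyl group gives a number 0.82 log units higher from compound 2 to compound 4 (beyond the scatter). Starting from the 3-chlorophenyl group, it gives a number 0.25 log units higher from compound 1 to compound 4 (within the scatter), so an unsubstituted phenethyl matches the 3-chlorophenyl group at this position, and a substituent on the aromatic ring is not required for a number at this level, a point that the three substituted phenyl groups alone could not show. No measurement available here explains these differences.

The compounds shown leave open how much of the rise from compound 3 belongs to the change of chain and how much to the loss of the methoxy group, as phenethyl changes both at once. Also open, from the compounds shown here alone, is how far this position accepts other groups, such as a longer chain, or a phenethyl carrying a chloro group or ending in an amine or a carboxylic acid.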